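Methylsulfonyl for sulfamoyl on a thiazolidinone amide

The source may hold more compounds than are shown below. What is called first, only, known or untested is meant among the compounds shown, and "the series" means these compounds.

Measured compounds:
compound 1, `CS(=O)(=O)c1ccc(NC(=O)CSc2nnc(N3C(=O)CSC3c3cccc(Cl)c3)s2)cc1`, 113000 nM
compound 2, `CS(=O)(=O)c1ccc(NC(=O)CSc2nnc(N3C(=O)CSC3c3ccccc3Cl)s2)cc1`, >= 172000 nM
compound 3, `NS(=O)(=O)c1ccc(NC(=O)CSc2nnc(N3C(=O)CSC3c3ccc(Cl)cc3)s2)cc1`, >= 222000 nM

Among the measured compounds shown here, compound 3 is the one with the sulfamoyl group. In an ADME assay on MT4 cells (Homo sapiens) for cytotoxicity, read by MTT assay, with a stated time of 5 days (on this read-out higher numbers stand for lower toxicity in this test and lower numbers for higher toxicity in this test), compound 3 reaches only a limit, >= 222000 nM, so no number for it is known; this is the limit of >= 222000 nM in this assay, at which 1 of the 3 values shown sits. Of the other two, compound 1 gives a number, 113000 nM, in this assay. For compound 2 the value is again a limit, >= 172000 nM, which is the limit of >= 172000 nM in this assay, at which 1 of the 3 values shown sits. For the measured compounds named here, the one measured step, an at least 1.5-fold higher number from compound 1 to compound 2 (0.18 log units; that floor lies within the scatter), concerns the chlorophenyl on the saturated ring carbon and not the sulfonyl group, and its floor lies within the scatter.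

Compound 4, `CS(=O)(=O)c1ccc(NC(=O)CSc2nnc(N3C(=O)CSC3c3ccc(Cl)cc3)s2)cc1`, differs from compound 3 by methyl in place of amino on a sulfonyl sulfur. Going by the values given here, no measured step covers that change, so the expectation for compound 4 rests on the three values together, all of which sit high in this assay. Compound 4 is therefore expected to show a step of an at least 1.3-fold lower number from compound 3 to compound 4 (0.11 log units; that floor lies within the scatter), that is, none beyond the scatter. For compound 4 a value of about 170000 nM is estimated, within 80000 nM to 300000 nM.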

Compound 4, half-maximal cytotoxic concentration: 116000 nM
Compound 4: the middle estimate sits 1.5-fold (0.17 log units) above what was measured; low and high end bracket the measured number.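

Among the compounds shown here, with compound 4, the change of methyl in place of amino on a sulfonyl sulfur can be read for the first time in this assay, but only as a floor, an at least 1.9-fold lower number from compound 3 to compound 4 (0.28 log units; that floor lies within the scatter), and the value of compound 3 is a limit and not a number: the limit of >= 222000 nM in this assay, at which 1 of the 4 values shown sits. Compound 4 also places the 4-chlorophenyl in the methylsulfonyl series, and against the 3-chlorophenyl the step is a 1.0-fold higher number from compound 1 to compound 4 (0.01 log units; within the scatter), so moving the chlorine between these two places on the phenyl leaves no difference that can be told apart in this read-out. Against the 2-chlorophenyl the step is an at least 1.4-fold lower number from compound 2 to compound 4 (0.17 log units; that floor lies within the scatter), which again gives only a floor, and the value of compound 2 is a limit and not a number: the limit of >= 172000 nM in this assay, at which 1 of the 4 values shown sits.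

Going by these compounds, how far compound 3 and compound 2 truly lie from compound 4 stays open, so neither the sulfamoyl group nor the 2-chlorophenyl can be said to differ from its replacement beyond the scatter. Whether a carboxylic acid or a nitrile on that phenyl, in place of the methylsulfonyl group, would shift the number in this assay is also left open.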